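The source may hold more compounds than are shown below. What is called first, only, known or untested is meant among the compounds shown, and "the series" means these compounds.

Values so far in a functional assay on NCI-H460 cells (Homo sapiens) for cytotoxicity, read by sulforhodamine B assay, with a stated time of 3 days; a higher number here means a weaker inhibitor, a lower number a stronger inhibitor

compound 1 `OCc1cn(Cc2ccc(Cl)cc2)c2ccccc12` gives 16 nM
compound 2 `OCc1cn(Cc2ccc(Cl)cc2Cl)c2ccccc12` gives 79 nM
compound 3 `COc1ccc2c(c1)c(CO)cn2Cc1ccc(Cl)cc1` gives 1510 nM

Compound 1 stands lowest of the three at 16 nM and is the strongest inhibitor measured so far in this assay on these numbers. Both measured steps raise the number: a 4.9-fold higher number from compound 1 to compound 2 (0.69 log units; beyond the scatter) with chloro in place of hydrogen on an aromatic carbon and a 94-fold higher number from compound 1 to compound 3 (1.97 log units; beyond the scatter) with methoxy in place of hydrogen on an aromatic carbon.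

The next compound is compound 4 `CC(=O)OCc1cn(Cc2ccc(Cl)cc2)c2ccccc12`. It keeps the core of compound 1 and changes hydroxymethyl to acetoxymethyl, with acetyl in place of hydrogen on an oxygen on a saturated carbon. For the measured compounds named here, neither measured step touches that oxygen, so the data hold no direct precedent. The two steps bear on it only loosely, showing that one substitution on compound 1 has so far moved the number upward, by a modest amount in one case and a large amount in the other. A small rise is therefore expected, most likely not beyond the scatter, though the range must stay wide. The estimated change is a 1.9-fold higher number from compound 1 to compound 4 (0.27 log units; within the scatter) in this reading. Compound 4 is expected at 30 nM with an estimated range from 8 nM to 130 nM here.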

Compound 4, half-maximal inhibitory concentration: 39 nM
Estimate against measurement, compound 4: 1.3-fold (0.11 log units) below; the range from low to high includes it.
By their numbers in this assay, from the lowest: compound 1; then compound 4; then compound 2; then compound 3.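

In this assay, for the compounds shown here, the oxygen of the hydroxymethyl group is the first site outside the aromatic carbons to be changed, and acetyl in place of its hydrogen gives a 2.4-fold higher number from compound 1 to compound 4 (0.39 log units; beyond the scatter), a modest loss that is beyond the scatter but much smaller than the step with methoxy on an aromatic carbon, a 94-fold higher number from compound 1 to compound 3 (1.97 log units; beyond the scatter). The free hydroxy hydrogen is therefore not required for activity in this series, since compound 4 still gives 39 nM with that position capped, though compound 1 remains the stronger of the pair. Nothing measured on these compounds accounts for the size of this step.

The compounds shown leave open how far this oxygen tolerates other groups, such as a methyl ether, a longer acyl chain like butanoyl, or a benzoyl ester, and whether replacing the hydroxy with an amine or the hydroxymethyl with a carboxylic acid would hold the number near that of compound 1. They also leave open whether acetyl on this oxygen has a similar effect when combined with the chloro or methoxy changes on the aromatic carbons.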